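Swapping the Dichlorophenyl of Compound 3 for Dimethoxyphenyl

The source may report more compounds than this note shows. Statements on the series, on what has been measured and on what is new or still open speak of the compounds shown alone.

The measured compounds, all in a functional assay on SNB-19 cells (Homo sapiens) for inhibition, read by sulforhodamine B assay, with a stated time of 48 h; a lower number here means a stronger inhibitor of growth, a higher number a weaker inhibitor of growth:
Compound 1 `Nc1cc(N)c2nc(-c3ccccc3)c(Oc3ccc(Cl)c(Cl)c3)nc2c1` gives 20900 nM.
Compound 3 `Nc1cc(N)c2nc(-c3ccccc3)c(NCc3ccc(Cl)c(Cl)c3)nc2c1` gives 22400 nM.
Compound 2 `CCOC(=O)[C@H](CCC(=O)O)NC(=O)c1ccc(CNc2nc3cc(N)cc(N)c3nc2-c2ccccc2)cc1` gives only a limit of the assay, < 100000 nM.

Of the two numbers shown, compound 3 stands next to compound 1, and the two lie within the usual scatter of each other, so no order between them can be read from these data. The value for compound 2 is a limit and not a number (the limit of < 100000 nM in this assay, at which 1 of the 3 values shown sits); it therefore says nothing about where compound 2 would fall relative to compound 3.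

Compound 4 `COc1ccc(CNc2nc3cc(N)cc(N)c3nc2-c2ccccc2)cc1OC` has not been measured. It differs from compound 3 in one place: 3,4-dimethoxyphenyl in place of 3,4-dichlorophenyl on a saturated chain carbon bound to a nitrogen on an aromatic ring. Going by the values given here, no pair of measured compounds shows what this kind of exchange does in this assay, so there is no measured step to lean on. The author expects a modest step from compound 3 to compound 4, a 1.4-fold higher number from compound 3 to compound 4 (0.15 log units; within the scatter), towards a weaker inhibition of growth, though a result within the scatter would not surprise. On that basis compound 4 is estimated at 32000 nM, with a range from 10000 nM to 100000 nM.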

Compound 4, concentration for 50% growth inhibition: 25700 nM
For compound 4 the middle estimate is 1.2-fold (0.10 log units) above the measured one; measured number inside the range.
By their numbers in this assay, from the lowest: compounds 1, 3 and 4 (each within the scatter of the next).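

In this assay, going by these compounds alone, the exchange at this place can now be read for the first time, and it gives a 1.1-fold higher number from compound 3 to compound 4 (0.06 log units; within the scatter). The earlier compounds shown here offered no measured step of any kind, whereas this pair sets 3,4-dimethoxyphenyl against 3,4-dichlorophenyl on a saturated chain carbon bound to a nitrogen on an aromatic ring, and the numbers cannot be told apart. The entering group carries hydrogen-bond acceptors and the leaving group carries none, yet this single pair shows no difference in growth inhibition that stands clear of the scatter, and nothing shown here gives a reason for that.

As far as these compounds go, whether an amine or a carboxylic acid in place of these groups on the ring, or a longer chain in place of the saturated chain carbon, would give a number beyond the scatter of compound 3 stays open. Compound 2, the one compound here that carries a carboxylic acid, offers no guide on this, since its value is only a limit: the limit of < 100000 nM in this assay, at which 1 of the 4 values shown sits.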